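Compound 1 to compound 4: replacing 2-hydroxyethyl

This account rests on a few compounds, and the source may have more. Where it says the series, first, only, none or still open, it means among the compounds named here.

Measured in a functional assay on HCT-116 cells (Homo sapiens) for cytotoxicity, read by fluorescence, with a stated time of 72 h; a higher number here means a weaker inhibitor, a lower number a stronger inhibitor:
- compound 1 `CC(C)c1n[nH]c2c(NCc3ccc(-c4ccccn4)cc3)nc(NCCO)nc12` gives 27 nM
- compound 2 `CC(C)c1n[nH]c2c(NCc3ccc(-c4ccccn4)cc3)nc(N3CCNCC3)nc12` gives 88 nM
- compound 3 `CC(C)c1n[nH]c2c(NCc3ccc(-c4ccccn4)cc3)nc(NCCN(C)C)nc12` gives 390 nM

Compound 1 holds the lowest number of the three, and its steps to both others lie beyond the scatter. Compound 4 `CC(C)c1n[nH]c2c(NCc3ccc(-c4ccccn4)cc3)nc(N[C@H]3CC[C@H](N)CC3)nc12` is not yet measured. It keeps the core of compound 1 and carries 4-aminocyclohexyl in place of 2-hydroxyethyl on a nitrogen on an aromatic ring.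

Within the data shown here, two measured steps bear on this change. The first is modest, a 3.3-fold higher number from compound 1 to compound 2 (0.51 log units; beyond the scatter), and the second is large, a 14-fold higher number from compound 1 to compound 3 (1.16 log units; beyond the scatter). Compound 2 and compound 3 both lack the hydroxy group of compound 1 and both sit higher, and compound 4 lacks it too. Neither carries a 4-aminocyclohexyl group, so the read-across is loose. The expected step is modest and upward, a 3.0-fold higher number from compound 1 to compound 4 (0.47 log units; beyond the scatter). For compound 4 the estimated value is 80 nM, with an expected range of 20 nM to 320 nM.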

Compound 4, half-maximal inhibitory concentration: 720 nM
The estimate for compound 4 lay 9.0-fold (0.95 log units) below the measured number; the measured number lies above the stated range.
By their numbers in this assay, from the lowest: compound 1; then compound 2; then compounds 3 and 4 (each within the scatter of the next).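

In this assay, the step to 4-aminocyclohexyl on this nitrogen gives a 27-fold higher number from compound 1 to compound 4 (1.43 log units; beyond the scatter), the largest step in the set so far, and the (2-hydroxyethyl)amino group of compound 1 keeps the lowest number. Carrying a ring at this position does not by itself set the number: compound 2 and compound 4 both carry one, yet the change gives an 8.2-fold higher number from compound 2 to compound 4 (0.91 log units; beyond the scatter). The open-chain 2-(dimethylamino)ethyl group of compound 3 gives a number close to that of the ring-bearing group, with a 1.8-fold higher number from compound 3 to compound 4 (0.27 log units; within the scatter).

No measured evidence accounts for the size of these steps. Still open, as far as these compounds go, is whether the hydroxy group or the ring matters more here, a question that 4-hydroxycyclohexyl on the same nitrogen would address directly.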